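Pyridine series: chlorofuran step on the furan-2-yl analogue

The compounds below may be only part of what the source reports. "The series", "measured", "known", "first", "only" and "open" are said of these compounds alone.

Measured so far:
compound 1 `Clc1ccc(-c2cc(-c3ccoc3)cc(-c3cccs3)n2)cc1`, 21100 nM
compound 2 `Cc1ccc(-c2cc(-c3ccc(Cl)o3)cc(-c3cccs3)n2)cc1`, 21500 nM
compound 3 `Clc1ccc(-c2cc(-c3ccco3)cc(-c3cccs3)n2)cc1`, > 100000 nM

In a functional assay on K562 cells (Homo sapiens) for cytotoxicity, in the presence of a further agent that is not named here (a lower number here means a stronger inhibitor, a higher number a weaker inhibitor), compound 3 gives only the limit > 100000 nM, not a number. Compounds 1 and 2 both give numbers in the same region. Going by the values given here, the one step measured in a single place, an at least 4.7-fold higher number from compound 1 to compound 3 (0.67 log units; beyond the scatter), moves from a number up to the limit (the limit of > 100000 nM in this assay, at which 1 of the 3 values shown sits).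

Compound 4 `Clc1ccc(-c2cc(-c3ccc(Cl)o3)cc(-c3cccs3)n2)cc1` is not yet measured. It differs from compound 3 by chloro in place of hydrogen on an aromatic carbon. Among the compounds with values here, no measured step covers this chloro change on its own; compound 2 carries the same 5-chlorofuran-2-yl group and gives a number, while compound 3 with plain furan-2-yl sits at the limit. The step of an at least 4.7-fold higher number from compound 1 to compound 3 (0.67 log units; beyond the scatter) does not bear on a chloro change and gives no direction for it. The estimate therefore leans on the number shown by compound 2: compound 4 is expected to return a number rather than a limit, with the expected step of an at least 3.3-fold lower number from compound 3 to compound 4 (0.52 log units; beyond the scatter) down from the limit of compound 3, though a second limit cannot be excluded. Compound 4 is estimated at 30000 nM, within 10000 nM to 100000 nM.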

Compound 4, half-maximal inhibitory concentration: 20900 nM
Estimate against measurement, compound 4: 1.4-fold (0.16 log units) above; the measured number falls inside the stated range.
By their numbers in this assay, from the lowest: compounds 4, 1 and 2 (each within the scatter of the next). At a limit, above all of these: compound 3.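

In this assay, 5-chlorofuran-2-yl in place of furan-2-yl takes the series from a limit back to a number, with an at least 4.7-fold lower number from compound 3 to compound 4 (0.67 log units; beyond the scatter). With this group in place, chloro in place of methyl on an aromatic carbon gives a 1.0-fold lower number from compound 2 to compound 4 (0.01 log units; within the scatter), and the exchange for furan-3-yl gives a 1.0-fold lower number from compound 1 to compound 4 (0.00 log units; within the scatter), so compounds 1, 2 and 4 all lie within the scatter of one another. The size of the chloro step is only a bound, since compound 3 stands at a limit: the limit of > 100000 nM in this assay, at which 1 of the 4 values shown sits.

On these data alone, whether a methyl, a bromo or an amine on this same furan carbon would also return a number stays open. Also open, as far as these compounds go, is whether chloro on the furan-3-yl group of compound 1 would move its number at all.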